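A few compounds are considered here, and "the series" means these few. Any claim that something is new, unique, unknown or untested is made for them only; others in the source may bear on it.

Measured compounds:
compound 1, `Oc1ccccc1-c1cc(-c2cccs2)cc(-c2ccccc2O)n1`, 77.2%
compound 2, `Oc1cccc(-c2cc(-c3cccs3)cc(-c3ccccc3O)n2)c1`, 83.2%
compound 3, `Oc1cccc(-c2cc(-c3ccsc3)cc(-c3ccccc3O)n2)c1`, 10.2%

Of the compounds shown here, three built on one shared core have been tested in an assay on isolated protein for inhibition of DNA topoisomerase 1 (Homo sapiens), with a stated time of 30 min, tested at 100 uM; a higher number here means a stronger effect of the compound at the concentration tested, a lower number a weaker effect. Compound 1 gives 77.2%, and compound 2, which differs from it by 3-hydroxyphenyl in place of 2-hydroxyphenyl on an aromatic carbon, gives 83.2%; the step of a number 6 percentage points higher from compound 1 to compound 2 (within the scatter) is small. Compound 3, with thiophen-3-yl in place of thiophen-2-yl on an aromatic carbon, gives 10.2%, and the step of a number 73 percentage points lower from compound 2 to compound 3 (beyond the scatter) is by far the largest seen here. The difference between the cores of compound 3 and compound 1 is not broken down here; their values simply show compound 3 far lower.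

Compound 4, `Oc1cccc(-c2cc(-c3ccsc3)cc(-c3cccc(O)c3)n2)c1`, has not yet been measured in this assay. It differs from compound 3 by 3-hydroxyphenyl in place of 2-hydroxyphenyl on an aromatic carbon. This is the same kind of change as that from compound 1 to compound 2, though the surroundings differ: in compound 1 the place is meta to a 2-hydroxyphenyl group and meta to a thiophen-2-yl group, whereas in compound 3 it is meta to a 3-hydroxyphenyl group and meta to a thiophen-3-yl group. Among the compounds with values here, the only precedent is the step of a number 6 percentage points higher from compound 1 to compound 2 (within the scatter), which lay within the scatter, so a step of similar small size is expected, a number 5.8 percentage points higher from compound 3 to compound 4 (within the scatter), starting from the low value of compound 3. Compound 4 is therefore estimated at 16%, with a range from 0% to 45%.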

Compound 4, a percentage reported as inhibition, at one concentration (the size of the read-out at that concentration, not a potency): 59.2%
Estimate against measurement, compound 4: 43.2 percentage points below; measured number outside the range, above it.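

In this assay, the change from 2-hydroxyphenyl to 3-hydroxyphenyl does not carry from one core to the other as a step of fixed size, and the new step, a number 49 percentage points higher from compound 3 to compound 4 (beyond the scatter), stands well apart from the earlier one: the same change on two cores in this assay, a number 6 percentage points higher (within the scatter) from compound 1 to compound 2 and a number 49 percentage points higher (beyond the scatter) from compound 3 to compound 4, 43 percentage points apart, beyond the scatter of two such steps The step is beyond the scatter only on the core of compound 3, where the starting value was low, so the effect of this change cannot be read from one core and simply transferred to another in this series. These two pairs do not show what sets the difference, since the two cores differ both in how the thiophene is attached and in the hydroxyphenyl group that stays in place, and the two pairs cannot separate those features.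

The compounds shown leave open which of those two features matters, and whether the same core dependence would appear on any further core. They also leave open how the series would respond if an amine or a carboxylic acid stood in place of the hydroxyl group on the phenyl ring that changes here.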